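This account rests on a few compounds, and the source may have more. Where it says the series, first, only, none or still open, it means among the compounds named here.

Measured in an ADME assay on BJ cells (Homo sapiens), read by MTT assay, with a stated time of 72 h (on this read-out lower numbers stand for stronger inhibition and higher numbers for weaker inhibition), each entry being a limit of the assay and not a number:

- compound 1 `CN(C)c1ncnc2c1c(-c1ccsc1)cn2[C@@H]1O[C@H](CO)[C@@H](O)[C@H]1O`: > 100000 nM
- compound 2 `Nc1nc(N)c2c(-c3ccco3)cn([C@@H]3O[C@H](CO)[C@@H](O)[C@H]3O)c2n1`: > 100000 nM
- compound 3 `COc1nc(N)nc2c1c(-c1ccco1)cn2[C@@H]1O[C@H](CO)[C@@H](O)[C@H]1O`: > 100000 nM

Compound 3 has no exact number in this assay, and its > 100000 nM is a limit. The whole set stands at one place: the limit of > 100000 nM in this assay, at which 3 of the 3 values shown sit.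

Compound 4 `COc1nc(N)nc2c1c(-c1ccoc1)cn2[C@@H]1O[C@H](CO)[C@@H](O)[C@H]1O` has the same atoms as compound 3, joined differently. It carries furan-3-yl in place of furan-2-yl on an aromatic carbon of a five-membered aromatic ring with 1 nitrogen (furan-3-yl in place of furan-2-yl on an aromatic carbon).

For the measured compounds named here, only one measured step touches compound 3, namely a step that the two limits leave unreadable from compound 2 to compound 3. That step is methoxy in place of amino on an aromatic carbon, a change elsewhere in the structure, and it offers no size to carry over. Going by the values given here, no measured pair makes the exchange between the two furan groups. With all three compounds at the limit, no step beyond the scatter is expected in this assay, and no direction can be given.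

The expected change is a number no higher from compound 3 to compound 4 (the limit leaves the size open), and the most likely report is again a limit. Compound 4 is estimated at 100000 nM, with an expected range from 30000 nM to 300000 nM.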

Compound 4, half-maximal inhibitory concentration: > 100000 nM
Compound 4 was reported as a limit (the forecaster's own chance of this, stated with the estimate: 75%); the middle value sits exactly at the limit.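

Compound 4 gives > 100000 nM in this assay, and this is a limit. The exchange of furan-2-yl for furan-3-yl between compound 3 and compound 4 therefore yields no readable step, and the whole set stands at one place: the limit of > 100000 nM in this assay, at which 4 of the 4 values shown sit.

The compounds shown leave open whether these structures differ at all in this assay, and in which direction.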